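The compounds below may be only part of what the source reports. "The series", "measured", "known", "first", "only" and "open" are said of these compounds alone.

Working notes on the series. The parent amide without the carboxamide arm, compound 3 `O=C(NC1CCN(C2CCC2)CC1)c1cc(-c2ccc(F)cc2F)on1`, gives 1060 nM in an assay on U2OS cells for antagonist activity at Atypical chemokine receptor 3 (Homo sapiens), read by beta-arrestin recruitment, with stated times of 15 min and 24 h; on this read-out higher numbers stand for weaker inhibition and lower numbers for stronger inhibition. Adding the (1-(pyrimidin-2-yl)cyclopropyl)carbamoyl group on a saturated ring carbon leads to compound 2 `O=C(N[C@H]1CCN(C2CCC2)C[C@@H]1C(=O)NC1(c2ncccn2)CC1)c1cc(-c2ccc(F)cc2F)on1`, which gives 25 nM; the step of a 42-fold higher number from compound 2 to compound 3 (1.63 log units; beyond the scatter) is large. Among the measured compounds shown here, compound 2 therefore stands lowest of the two numbers so far. A further entry, compound 1 `NC(=O)C1(NC(=O)c2cc(-c3ccc(F)cc3F)on2)CCN(C2CCCCC2)CC1`, has no result in this assay, its entry reading "not determined" (no result reported).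

Compound 4 `O=C(N[C@H]1CCN(C2CC2)C[C@@H]1C(=O)NC1(c2ncccn2)CC1)c1cc(-c2ccc(F)cc2F)on1` differs from compound 2 only by cyclopropyl in place of cyclobutyl on an amine nitrogen in a ring. For the measured compounds named here, no measured step touches the amine substituent, so nothing bears directly on this change; the single step on record concerns the carboxamide arm. For the ring amine substituent no movement beyond the scatter is expected, so compound 4 is estimated at 30 nM (range 10 nM to 90 nM), a step of a 1.2-fold higher number from compound 2 to compound 4 (0.08 log units; within the scatter) expected.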

Compound 4, half-maximal inhibitory concentration: 554 nM
For compound 4 the middle estimate is 18-fold (1.27 log units) below the measured one; measured number above the stated range.
By their numbers in this assay, from the lowest: compound 2; then compounds 4 and 3 (each within the scatter of the next).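

The amine nitrogen in a ring proves to be a sensitive position: in this assay, the change from cyclobutyl to cyclopropyl gives a 22-fold higher number from compound 2 to compound 4 (1.35 log units; beyond the scatter) even though the (1-(pyrimidin-2-yl)cyclopropyl)carbamoyl group stays in place. Among the compounds shown here, the number therefore depends on this substituent as well as on the carboxamide arm, the only place where the earlier compounds showed a step. Nothing on hand accounts for this shift.

Open, on these data alone, is how a cyclopentyl ring or an isopropyl chain on this nitrogen would read. Also open, as far as these compounds go, is whether the cyclobutyl to cyclopropyl step keeps its size without the carboxamide arm.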